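A few compounds are considered here, and "the series" means these few. Any claim that something is new, unique, unknown or untested is made for them only; others in the source may bear on it.

Measured in a physicochemical assay for solubility, read by nephelometry, at pH 7.4; on this read-out higher numbers stand for higher solubility and lower numbers for lower solubility:
- compound 1 `COc1cccc(NC(=O)c2nnn(Cc3ccc([S+](C)[O-])cc3)c2N)c1`: > 250000 nM
- compound 2 `COc1cccc(NC(=O)c2nnn(CC3CCNCC3)c2N)c1`: > 250000 nM
- compound 3 `COc1cccc(NC(=O)c2nnn(C(C)c3ccc(C(C)(C)C)cc3)c2N)c1`: 20000 nM

Compound 1 stands at the limit of > 250000 nM in this assay, at which 2 of the 3 values shown sit; this is a limit of the assay and not a number. The value of compound 2 is also a limit. Going by the values given here, the one measured step is therefore a step that the two limits leave unreadable from compound 1 to compound 2, and it gives no size to carry forward.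

Compound 4 `COc1cccc(NC(=O)c2nnn(Cc3ccc(OC(F)(F)F)cc3)c2N)c1` carries trifluoromethoxy on an aromatic carbon of a six-membered aromatic ring of carbon only, para to a large group, in place of the group in compound 1: a group of 5 heavy atoms (1 carbon, 1 oxygen, 3 fluorine; no ring) in place of a group of 3 heavy atoms (1 carbon, 1 oxygen, 1 sulfur; no ring), on an aromatic carbon. Among the compounds with values here, no measured step covers this change. Within the data shown here, the only numerical reading is from compound 3 at 20000 nM, so the expectation for compound 4 leans towards that value, though with wide uncertainty. A fall in this assay is expected, towards lower solubility, and the expected change is an at least 5.0-fold lower number from compound 1 to compound 4 (0.69 log units; beyond the scatter). For compound 4 the estimated value is 50000 nM, with an expected range from 15000 nM to 200000 nM.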

Compound 4, solubility: 12000 nM
The estimate for compound 4 lay 4.2-fold (0.62 log units) above the measured number; measured number outside the range, below it.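

In this assay, trifluoromethoxy on an aromatic carbon, para to a large group, in place of the sulfur-bearing group gives an at least 20-fold lower number from compound 1 to compound 4 (1.31 log units; beyond the scatter). The value of compound 1 is a limit and not a number, so this step has a floor and no upper end: the limit of > 250000 nM in this assay, at which 2 of the 4 values shown sit. Going by these compounds alone, this is the first readable result for a change in this one place; the earlier step between limits cannot be read, and compound 3 differs from compound 1 in more than one place.

The compounds shown leave open whether this fall is particular to trifluoromethoxy or would also follow other groups at this position. An amine, a carboxylic acid or a methoxy group on the same aromatic carbon, with the rest of compound 1 kept, would test how far the read-out depends on the group that enters.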